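Swapping a Five-Membered Amine Ring for a Six-Membered One

The source may report more compounds than this note shows. Statements on the series, on what has been measured and on what is new or still open speak of the compounds shown alone.

Of the compounds shown here, three sharing one core have been measured in a functional assay on NCI-H460 cells (Homo sapiens) for cytotoxicity, read by MTT assay, with a stated time of 72 h; on this read-out higher numbers stand for weaker inhibition and lower numbers for stronger inhibition. Compound 1 `COc1cc2c(Oc3ccc(NC(=O)c4cc(-c5ccc(F)cc5)ccn4)cc3F)ccnc2cc1OCCCN1CCCCC1` gives 250 nM. Among the compounds with values here, compound 2 `COc1cc2c(Oc3ccc(NC(=O)c4cc(-c5ccccc5F)ccn4)cc3F)ccnc2cc1OCCCN1CCCCC1` gives 130 nM, and the only single-point step measured, a 1.9-fold lower number from compound 1 to compound 2 (0.28 log units; within the scatter), concerns the fluorophenyl. Compound 3 `COc1cc2c(Oc3ccc(NC(=O)c4cc(-c5ccccc5)ccn4)cc3F)ccnc2cc1OCCCN1CCCC1` gives 130 nM, the same digits as compound 2, and its gap to compound 1 stays within the scatter.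

Compound 4 `COc1cc2c(Oc3ccc(NC(=O)c4cc(-c5ccccc5)ccn4)cc3F)ccnc2cc1OCCCN1CCCCC1` differs from compound 3 by piperidin-1-yl in place of pyrrolidin-1-yl on a saturated chain carbon, three bonds along the chain from an oxygen on an aromatic ring. Within the data shown here, no measured step touches this part of the molecule, so nothing in the data points to a change in either direction, and a step within the scatter is expected. Compound 4 is therefore estimated at 140 nM, within 55 nM to 360 nM. The expected step is a 1.1-fold higher number from compound 3 to compound 4 (0.03 log units; within the scatter).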

Compound 4, half-maximal inhibitory concentration: 120 nM
Compound 4: middle estimate off by 1.2-fold (0.07 log units), on the high side, within the range that was stated.
By their numbers in this assay, from the lowest: compounds 4, 2, 3 and 1 (each within the scatter of the next, the first and the last beyond it).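

Exchanging the rings at the end of the chain gives a 1.1-fold lower number from compound 3 to compound 4 (0.03 log units; within the scatter), so in this series piperidin-1-yl and pyrrolidin-1-yl cannot be told apart at this position. Removing the fluoro gives a 1.1-fold lower number from compound 2 to compound 4 (0.03 log units; within the scatter) and a 2.1-fold lower number from compound 1 to compound 4 (0.32 log units; beyond the scatter), and only the second of these steps, a modest one, clears the scatter. No measurement here explains either result.

Still open, from the compounds shown here alone, is how an amine of another kind, such as morpholin-4-yl or dimethylamino, would behave at the end of this chain. A shorter or longer chain carrying piperidin-1-yl also remains untested in the compounds shown.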